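This account rests on a few compounds, and the source may have more. Where it says the series, first, only, none or still open, it means among the compounds named here.

Compound 2 `O=C(/C(=C\c1ccc(Oc2ccccc2)cc1)Sc1ccc(Br)cc1)c1ccc(Br)cc1` stands highest of the three numbers measured in a functional assay on DU-145 cells (Homo sapiens) for inhibition, read by trypan blue exclusion, with a stated time of 96 h; on this read-out lower numbers stand for stronger inhibition of growth and higher numbers for weaker inhibition of growth: compound 2 gives 50000 nM, while compound 1 `O=C(/C(=C\c1ccc(Cl)cc1)Sc1ccc(Br)cc1)c1ccc(Br)cc1` gives 1000 nM and compound 3 `O=C(/C(=C\c1ccc(Br)cc1)Sc1ccc(Br)cc1)c1ccc(Br)cc1` gives 1000 nM. Compound 4 `Cc1ccc(S/C(=C/c2ccc(Oc3ccccc3)cc2)C(=O)c2ccc(Br)cc2)cc1` differs from compound 2 in one place: methyl in place of bromo on an aromatic carbon. For the measured compounds named here, none of the measured steps touches the ring where this change falls; they all concern the other ring, where a 50-fold higher number from compound 1 to compound 2 (1.70 log units; beyond the scatter) and no change at the digits printed from compound 1 to compound 3 (within the scatter). Going by the values given here, with no step bearing directly on this change, the expectation is for little movement in this assay, so the step from compound 2 to compound 4 is expected to be no change at the digits printed from compound 2 to compound 4 (within the scatter). Compound 4 is therefore estimated at 50000 nM, within a range from 15000 nM to 150000 nM.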

Compound 4, concentration for 50% growth inhibition: 1000 nM
For compound 4 the middle estimate is 50-fold (1.70 log units) above the measured one; the measured number lies below the stated range.
By their numbers in this assay, from the lowest: compounds 1, 3 and 4 (each within the scatter of the next); then compound 2.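

In this assay, for the compounds shown here, changing (4-bromophenyl)sulfanyl to (4-methylphenyl)sulfanyl gives a 50-fold lower number from compound 2 to compound 4 (1.70 log units; beyond the scatter), so this position, the same in all the earlier compounds, can clearly shift growth inhibition. The swap exchanges one heavy atom for one heavy atom, yet the step is large. Nothing available explains why this swap has such an effect. On these data alone, it remains open whether methyl in place of bromo at this position would also shift the number in compound 1 or compound 3, which lack the phenoxy group. As far as these compounds go, what an amine or a methoxy group would do here also remains open.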